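Swapping isopropyl for propyl on an amide nitrogen

The source may report more compounds than this note shows. Statements on the series, on what has been measured and on what is new or still open speak of the compounds shown alone.

Among the measured compounds shown here, in a functional assay on MCF7 cells (Homo sapiens) for antiproliferative activity, read by CCK-8 assay, with a stated time of 72 h (on this read-out higher numbers stand for weaker inhibition of growth and lower numbers for stronger inhibition of growth), compound 1 `CCC1C(=O)N(C)c2cnc(-n3ccc4cc(C(=O)NC(C)C)ccc43)nc2N1c1ccn(C)n1` gives 8420 nM, the higher of the two numbers so far. Compound 2 `CCCCNS(=O)(=O)c1ccc(Nc2ncc3c(n2)N(C2CCCC2)[C@H](CC)C(=O)N3C)cc1`, a differently built molecule, gives 459 nM, a gap beyond the scatter. Compound 3 `CCCNC(=O)c1ccc2c(ccn2-c2ncc3c(n2)N(c2ccn(C)n2)C(CC)C(=O)N3C)c1` has the same atoms as compound 1, joined differently, with propyl in place of isopropyl on an amide-type nitrogen. For the measured compounds named here, no measured pair shows this change, so no shift beyond the scatter is expected in this assay, and the estimated step is a 1.2-fold lower number from compound 1 to compound 3 (0.08 log units; within the scatter). For compound 3 the expected value is 7000 nM, within an estimated range of 2500 nM to 20000 nM.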

Compound 3, concentration for 50% growth inhibition: 6420 nM
Compound 3: middle estimate off by 1.1-fold (0.04 log units), on the high side; low and high end bracket the measured number.
By their numbers in this assay, from the lowest: compound 2; then compounds 3 and 1 (each within the scatter of the next).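

With the amide-type nitrogen carrying propyl in place of isopropyl, this assay gives a 1.3-fold lower number from compound 1 to compound 3 (0.12 log units; within the scatter) and so does not separate the two compounds. Among the compounds shown here, this is the first direct test of this position, and on the shared core this rearrangement of the three carbons leaves growth inhibition within the usual scatter. No measurement available here offers an explanation for this result.

As far as these compounds go, whether a longer chain such as pentyl, a cyclopropyl ring or a chain ending in an amine on this nitrogen would shift the number remains open.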